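From Methoxy to Ethoxy at the Edge of Activity

The source may report more compounds than this note shows. Statements on the series, on what has been measured and on what is new or still open speak of the compounds shown alone.

Among the measured compounds shown here, in a functional assay on HL-60 cells (Homo sapiens) for antiproliferative activity, read by MTT assay, with a stated time of 72 h (on this read-out higher numbers stand for weaker inhibition and lower numbers for stronger inhibition), compound 1 `COc1ccc(-c2ncnn2-c2cc(OC)c(OC)c(OC)c2)cc1` gives 120 nM, the only actual number among the measured compounds. Compound 2 `COc1cccc(-c2ncnn2-c2cc(OC)c(OC)c(OC)c2)c1` reads > 10000 nM, which is a limit of the assay. Compound 3 `COc1cc(-n2ncnc2-c2ccc(Cl)c(Cl)c2)cc(OC)c1OC` reads > 10000 nM, also a limit. Replacing the 4-methoxyphenyl group with 3-methoxyphenyl gives an at least 83-fold higher number from compound 1 to compound 2 (1.92 log units; beyond the scatter), and replacing it with 3,4-dichlorophenyl gives an at least 83-fold higher number from compound 1 to compound 3 (1.92 log units; beyond the scatter).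

Compound 4 `CCOc1ccc(-c2ncnn2-c2cc(OC)c(OC)c(OC)c2)cc1` differs more slightly: methyl in place of hydrogen on a saturated chain carbon bound to an oxygen on an aromatic ring, turning methoxy to ethoxy. Neither measured step makes this exact change, but both bear on it as warnings that changes to this group can cost much of the activity. Compound 4 alters the group far less than either of those changes, so a modest move toward a higher number in this assay is expected, perhaps not beyond the scatter. The expected step is a 1.7-fold higher number from compound 1 to compound 4 (0.22 log units; within the scatter). For compound 4, the estimated value is 200 nM, with an expected range from 40 nM to 1500 nM.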

Compound 4, half-maximal inhibitory concentration: 20 nM
Compound 4: middle estimate off by 10-fold (1.00 log units), on the high side, outside the stated range (below it).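

In this assay, the change from methoxy to ethoxy gives a 6.0-fold lower number from compound 1 to compound 4 (0.78 log units; beyond the scatter), so methyl in place of hydrogen on a saturated chain carbon bound to an oxygen on an aromatic ring goes with stronger inhibition. The earlier steps shown here showed only losses, and they replaced the whole 4-methoxyphenyl group, whereas this smaller change to the same group moves the number the other way. It is also the only step here read between two actual numbers rather than against a limit: the limit of > 10000 nM in this assay, at which 2 of the 4 values shown sit.

Going by these compounds, whether the gain carries on to a longer chain such as propoxy, or to a branched one such as isopropoxy, stays open. The compounds shown also do not tell why ethoxy gives the lower number, and the step between compound 2 and compound 3 cannot be read.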